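Swapping the benzyl for a propyl on the thioether sulfur

The compounds below may be only part of what the source reports. "The series", "measured", "known", "first", "only" and "open" are said of these compounds alone.

Three compounds share one core and differ only at the sulfur. In a functional assay on A549 cells (Homo sapiens) for antiproliferative activity, read by CCK-8 assay, with a stated time of 48 h (a higher number here means a weaker inhibitor, a lower number a stronger inhibitor), compound 1 `O=c1c2ccccc2[se]n1-c1nc(SCc2ccc(F)cc2)n[nH]1` gives 36400 nM, compound 2 `CC(C)Sc1n[nH]c(-n2[se]c3ccccc3c2=O)n1` gives 36600 nM, and compound 3 `Cc1ccccc1CSc1n[nH]c(-n2[se]c3ccccc3c2=O)n1` gives 9720 nM, the lowest of the three numbers. The change from compound 1 to compound 2 was a 1.0-fold higher number from compound 1 to compound 2 (0.00 log units; within the scatter), whereas a 3.8-fold lower number from compound 2 to compound 3 (0.58 log units; beyond the scatter) and a 3.7-fold lower number from compound 1 to compound 3 (0.57 log units; beyond the scatter) both set compound 3 apart. Compound 4 `CCCSc1n[nH]c(-n2[se]c3ccccc3c2=O)n1` differs from compound 3 by ethyl in place of 2-methylphenyl on a saturated chain carbon bound to a sulfur. The step from compound 2 to compound 3 bears most directly on this, since propyl resembles isopropyl; the reverse move is therefore expected, a modest rise beyond the scatter. Compound 4 is expected to give about 32000 nM, with a range from 13000 nM to 80000 nM. That would mean an expected step of a 3.3-fold higher number from compound 3 to compound 4 (0.52 log units; beyond the scatter).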

Compound 4, half-maximal inhibitory concentration: 45500 nM
Beside the measured number, compound 4's estimate is 1.4-fold (0.15 log units) below it; measured number inside the range.
By their numbers in this assay, from the lowest: compound 3; then compounds 1, 2 and 4 (each within the scatter of the next).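

Going to propyl gives a 4.7-fold higher number from compound 3 to compound 4 (0.67 log units; beyond the scatter) and removes the edge held by the 2-methylbenzyl group, while a 1.2-fold higher number from compound 2 to compound 4 (0.09 log units; within the scatter) and a 1.3-fold higher number from compound 1 to compound 4 (0.10 log units; within the scatter) leave propyl level with isopropyl and 4-fluorobenzyl. Of the four groups on the sulfur, only 2-methylbenzyl stands apart, and the straight chain reads like the branched chain. No measurement offered here explains this. As far as these compounds go, whether the methyl matters or any benzyl with the right substituent would do stays open, with unsubstituted benzyl the obvious comparison. From the compounds shown here alone, how a longer chain or an amine-bearing chain would read also stays open.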